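The source may hold more compounds than are shown below. What is called first, only, known or untested is meant among the compounds shown, and "the series" means these compounds.

Measured compounds:
compound 1 `c1ccc(CCc2ccccc2CSc2nccs2)cc1`: 31%
compound 2 `c1ccc(CCc2ccccc2CSC2=NCCN2)cc1`: 17%
compound 3 `c1ccc(CCc2ccccc2CSC2=NCCS2)cc1`: 0%

All three values come from an assay on isolated protein for inhibition of Indoleamine 2,3-dioxygenase 1 (Homo sapiens), with a stated time of 60 min, tested at 10 uM; a lower number here means less inhibition, a higher number more inhibition at the concentration tested (going by the name of the read-out). Compound 3 stands lowest of the three: it sits a number 17 percentage points lower from compound 2 to compound 3 (beyond the scatter) and a number 31 percentage points lower from compound 1 to compound 3 (beyond the scatter). Compound 4 `c1ccc(CCc2ccccc2CSc2ncc[nH]2)cc1` differs from compound 3 by a group of 5 heavy atoms (3 carbon, 2 nitrogen; one five-membered aromatic ring with 2 hetero atoms) in place of a group of 5 heavy atoms (3 carbon, 1 nitrogen, 1 sulfur; one five-membered non-aromatic ring with 2 hetero atoms), on a sulfur. The step bearing most on this is the one in which the aromatic ring gave way to a non-aromatic one, a number 31 percentage points lower from compound 1 to compound 3 (beyond the scatter), and the smaller drop a number 14 percentage points lower from compound 1 to compound 2 (beyond the scatter) points the same way. Returning to an aromatic ring, as in compound 4, is therefore expected to raise the percentage inhibition, by an estimated a number 22 percentage points higher from compound 3 to compound 4 (beyond the scatter). Compound 4 is estimated to give 22%, within 5% to 40%.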

Compound 4, a percentage reported as inhibition, at one concentration (the size of the read-out at that concentration, not a potency): 19%
Compound 4: middle estimate off by 3 percentage points, on the high side, within the range that was stated.
By their numbers in this assay, from the lowest: compound 3; then compounds 2 and 4 (each within the scatter of the next); then compound 1.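

With 1H-imidazol-2-yl on the sulfur, the inhibition is restored relative to the non-aromatic ring of the sulfur-containing compound (a number 19 percentage points higher from compound 3 to compound 4 (beyond the scatter)), but 1,3-thiazol-2-yl remains ahead of it (a number 12 percentage points lower from compound 1 to compound 4 (beyond the scatter)). An aromatic ring alone therefore does not set the value at this position, since the imidazolyl group and its non-aromatic two-nitrogen counterpart cannot be separated (a number 2 percentage points higher from compound 2 to compound 4 (within the scatter)). No evidence is available that explains these differences. Still open, from the compounds shown here alone, is how a methyl on the ring nitrogen of 1H-imidazol-2-yl, or an oxygen in place of the sulfur, would change the inhibition.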